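The compounds below may be only part of what the source reports. "The series", "measured", "known", "first", "only" and "open" are said of these compounds alone.

Three compounds built on a shared core were tested in an ADME assay on PC-3 cells (Homo sapiens) for cytotoxicity, read by WST assay, tested at 100 uM; on this read-out higher numbers stand for more inhibition at the one concentration tested (going by the name of the read-out) and lower numbers for less inhibition. Compound 1 `Cc1cccc(C(=O)N2CCCC(C(=O)Nc3ccc(Cl)cc3)C2)c1` gives 0%. Compound 2 `CC(=O)c1cccc(NC(=O)C2CCCN(C(=O)c3cc(C(F)(F)F)cc(C(F)(F)F)c3)C2)c1` gives 0%, and compound 3 `O=C(c1ccccc1)c1cccc(NC(=O)C2CCCN(C(=O)c3cc(C(F)(F)F)cc(C(F)(F)F)c3)C2)c1` gives 0%. Within the data shown here, the single one-place step among the measured compounds, no change at the digits printed from compound 2 to compound 3 (within the scatter), phenyl in place of methyl on a carbonyl carbon, stays within the scatter. On these numbers compound 1 stands level with compounds 2 and 3 at the digits shown, nearest to compound 2 and furthest from compound 3, both without any change beyond the scatter.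

Compound 4 `O=C(Nc1ccc(Cl)cc1)C1CCCN(C(=O)c2cccc([N+](=O)[O-])c2)C1` differs from compound 1 by a single exchange: nitro in place of methyl on an aromatic carbon. Among the measured compounds shown here, none of the measured steps touches that part of the structure; the one step available altered a group on a carbonyl carbon of a different ring and was flat. All three measured compounds sit at the floor of the read-out, and nothing in the data shows any exchange that moves it. The expectation for compound 4 is therefore no step beyond the scatter in this assay. Compound 4 is expected to give 0%, within a range from 0% to 12%, which means an expected step of no change at the digits printed from compound 1 to compound 4 (within the scatter).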

Compound 4, a percentage reported as inhibition, at one concentration (the size of the read-out at that concentration, not a potency): 0%
Compound 4: the middle estimate sits on the measured number at the digits printed; measured number inside the range.
By their numbers in this assay, from the lowest: compounds 1, 2, 3 and 4 (each within the scatter of the next).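

In this assay, among these compounds, the exchange on the aromatic carbon meta to a large group, nitro in place of methyl, gives no change at the digits printed from compound 1 to compound 4 (within the scatter), so this position, which no earlier step had touched, now has one exchange on record. The entering nitro brings hydrogen-bond acceptors and a double bond that methyl lacks, yet compound 4 gives 0%, and the step at the other end of the molecule likewise shows no change at the digits printed from compound 2 to compound 3 (within the scatter). No measurement shown here accounts for the flat result at this position.

With all four compounds at the floor, these results cannot show whether any exchange at this position would lift the read-out, and the answer could differ for an amine or a carboxylic acid in place of the nitro on the same aromatic carbon. They also leave open whether a longer chain at this place, or either of those groups at another place on the ring, would give any reading above the floor in this assay at all.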